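Replacing the fluorophenyl ketone with a cyclopropyl ketone

This account rests on a few compounds, and the source may have more. Where it says the series, first, only, none or still open, it means among the compounds named here.

Compound 1 `COc1cc(-c2nnc3n2NC(c2ccco2)C(C(=O)c2ccccc2F)S3)cc(OC)c1OC` and compound 2 `COc1cc(-c2nnc3n2NC(c2ccco2)C(C(=O)c2ccc(F)cc2)S3)cc(OC)c1OC` share one core and differ only in the aryl group on the carbonyl carbon. In a functional assay on HepG2 cells (Homo sapiens) for cytotoxicity, read by MTT assay, with a stated time of 48 h (on this read-out higher numbers stand for weaker inhibition and lower numbers for stronger inhibition), compound 1 gives > 100000 nM, which is a limit of the assay and not a number. Compound 2 likewise returns > 100000 nM in this assay, again a limit. The change from compound 1 to compound 2 is a step that the two limits leave unreadable from compound 1 to compound 2, 4-fluorophenyl in place of 2-fluorophenyl on a carbonyl carbon; because of the limit of > 100000 nM in this assay, at which 2 of the 2 values shown sit, no size can be read from it. Compound 3 `COc1cc(-c2nnc3n2NC(c2ccco2)C(C(=O)C2CC2)S3)cc(OC)c1OC` carries cyclopropyl in place of 4-fluorophenyl on a carbonyl carbon. Going by the values given here, no measured step bears on this change in a readable way, and nothing points to a value past the limit. Compound 3 is therefore expected to give 100000 nM, within 40000 nM to 300000 nM, most likely again reported as a limit. The expected step is a number no higher from compound 2 to compound 3 (the limit leaves the size open), none beyond the scatter.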

Compound 3, half-maximal inhibitory concentration: > 100000 nM
Compound 3 gave a limit, no number; the forecaster's own chance of this, stated with the estimate: 75%; the middle value sits exactly at the limit.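

No step can be read among compound 1, compound 2 and compound 3 in this assay, because each gives a limit of the assay and not a number: the limit of > 100000 nM in this assay, at which 3 of the 3 values shown sit.

The compounds shown leave open whether any group on the carbonyl carbon of the shared core gives a readable value in this assay.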